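Propyl to octyl: working notes on compound 3

The source may report more compounds than this note shows. Statements on the series, on what has been measured and on what is new or still open speak of the compounds shown alone.

Compound 2 `CCCOP(=O)(O)OCCSC(=S)N1CCCCC1` reads > 100000 nM in an ADME assay on HEK293 cells (Homo sapiens) for inhibition, read by MTT assay, with stated times of 18 h and 4 h; on this read-out lower numbers stand for stronger inhibition and higher numbers for weaker inhibition. That value is a limit of the assay and not a number. The series therefore stands, for compound 2, at the limit of > 100000 nM in this assay, at which 1 of the 2 values shown sits, and no true potency can be read for it.

Among the compounds with values here, compound 1 `CCCCCCCCOP(=O)(O)OCCSC(=S)N1CCCC1` gives 28300 nM in this assay, the only true number so far.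

Compound 3 `CCCCCCCCOP(=O)(O)OCCSC(=S)N1CCCCC1` carries pentyl in place of hydrogen on a saturated chain carbon, three bonds along the chain from an oxygen on an unsaturated carbon. The same difference reads as propyl to octyl.

Within the data shown here, no step between measured compounds is available, so the size of this change rests on thin ground. The expectation leans on compound 1 at 28300 nM, which shows that a number can be reached in this series. The expected step of an at least 4.0-fold lower number from compound 2 to compound 3 (0.60 log units; beyond the scatter) points toward stronger inhibition and is expected to exceed the usual scatter, although the limit leaves its true size open. For compound 3 the estimated value is 25000 nM, with an expected range from 10000 nM to 60000 nM.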

Compound 3, half-maximal inhibitory concentration: 69000 nM
The estimate for compound 3 lay 2.8-fold (0.44 log units) below the measured number; the whole stated range lies below it.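

Compound 2 remains a limit of the assay and not a number: the limit of > 100000 nM in this assay, at which 1 of the 3 values shown sits.

In this assay, as far as these compounds go, pentyl in place of hydrogen at this place now has a lower bound, an at least 1.4-fold lower number from compound 2 to compound 3 (0.16 log units; that floor lies within the scatter), so the direction toward stronger inhibition is suggested but the true size of the step stays open. The group on the thiocarbonyl carbon also gets its first readable comparison with octyl held fixed: piperidin-1-yl in place of pyrrolidin-1-yl gives a 2.4-fold higher number from compound 1 to compound 3 (0.39 log units; beyond the scatter), which on this read-out means weaker inhibition.

The compounds shown leave open how the number moves along the chain, since only propyl and octyl appear at this place, and butyl, hexyl or a longer chain such as dodecyl would be needed to tell a gradual change from an abrupt one or to show whether the trend continues past octyl. They also leave open whether the step from pyrrolidin-1-yl to piperidin-1-yl holds with other chains, and how a morpholin-4-yl or a dimethylamino group on the thiocarbonyl carbon would read.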